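Taking the formyl group off compound 3

The compounds below may be only part of what the source reports. "The series", "measured", "known", "first", "only" and "open" are said of these compounds alone.

Values in an ADME assay on HEK293 cells (Homo sapiens) for cytotoxicity, with a stated time of 72 h (on this read-out lower numbers stand for an effect already at smaller amounts and higher numbers for an effect only at larger amounts of compound), so far:
compound 1 `C=C[C@](C)(CCCC(C)C)CCc1ccc(O)cc1` gives > 36600 nM
compound 2 `C=C[C@@](C)(/C=C/c1ccc(O)cc1)CC/C=C(\C)C(=O)OCC` gives > 36600 nM
compound 3 `COc1ccc(/C=C/[C@@](C)(/C=C/c2ccc(O)c(C=O)c2)CCC=C(C)C)cc1` gives 2270 nM

Compound 1 has the entry > 36600 nM, which is a limit of the assay and not a number. The same holds for compound 2 with > 36600 nM as its entry. Going by the values given here, compound 3, at 2270 nM in this assay, is therefore the only compound with an actual number.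

The next compound to be tested is compound 4 `COc1ccc(/C=C/[C@@](C)(/C=C/c2ccc(O)cc2)CCC=C(C)C)cc1`, which carries hydrogen in place of formyl on an aromatic carbon, ortho to a hydroxy group and meta to a large group hydrogen in place of formyl on an aromatic carbon in an otherwise unchanged structure. Put another way, 3-formyl-4-hydroxyphenyl becomes 4-hydroxyphenyl.

Among the compounds with values here, no two measured compounds differ in one place only, so this change has no direct precedent here. Within the data shown here, the only guide is thin: compound 3 alone carries a formyl group, while compound 1 and compound 2 lack it and also differ from compound 4 elsewhere. Three compounds are too few for a rule, but they point one way. The expected change a 6.2-fold higher number from compound 3 to compound 4 (0.79 log units; beyond the scatter) is toward higher numbers and beyond the usual scatter, and it may even reach the limit of the assay. The estimated value for compound 4 is 14000 nM (expected range 4000 nM to 36600 nM).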

Compound 4, half-maximal effective concentration: > 36600 nM
Compound 4: a limit, no number (the forecaster's own chance of this, stated with the estimate: 35%); middle value at least 2.6-fold (0.41 log units) away from the limit.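

Going by these compounds alone, this is the first comparison here in which only one place differs, so the formyl group can be looked at on its own. In this assay, putting hydrogen in place of formyl on the aromatic carbon ortho to the hydroxy group gives an at least 16-fold higher number from compound 3 to compound 4 (1.20 log units; beyond the scatter). Compound 4 gives > 36600 nM, which is a limit of the assay and not a number. With the rest of the structure unchanged, the formyl group alone separates compound 3, the only compound with an actual number, from a compound without one, and the size of this step can be given only as a lower bound: the limit of > 36600 nM in this assay, at which 3 of the 4 values shown sit.

The compounds shown leave open whether the formyl group itself is needed, or whether another group at this place, such as a carboxylic acid, a hydroxymethyl group or an amine, would also give a number in this assay. They also leave open whether adding formyl at this place to the different chains of compound 1 and compound 2 would have the same effect, and they do not say why this group matters.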